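A few compounds are considered here, and "the series" means these few. Any claim that something is new, unique, unknown or untested is made for them only; others in the source may bear on it.

Three related compounds have been tested in a functional assay on OE19 cells (Homo sapiens) for cytotoxicity, read by MTT assay, with a stated time of 48 h; on this read-out lower numbers stand for stronger inhibition and higher numbers for weaker inhibition. Compound 1 `CC1(C)S[C@@H]2/C(=C\C(=O)c3ccco3)C(=O)N2[C@H]1C(=O)OC(c1ccccc1)c1ccccc1` gives 54300 nM in this assay. Compound 2 `CC1(C)S[C@@H]2C/C(=C\C(=O)c3ccccc3)C(=O)N2[C@H]1C(=O)OC(c1ccccc1)c1ccccc1` gives 73300 nM. Compound 3 `CC1(C)S[C@@H]2/C(=C\C(=O)c3ccc([N+](=O)[O-])cc3)C(=O)N2[C@H]1C(=O)OC(c1ccccc1)c1ccccc1` gives 44100 nM. Among these three, compound 3 holds the lowest number, but the step of a 1.2-fold lower number from compound 1 to compound 3 (0.09 log units; within the scatter) lies within the scatter, and the gap between compound 3 and compound 2 is also within the scatter, so the three cannot be told apart on these data.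

Compound 4 `CC(=O)/C=C1/C(=O)N2[C@@H]1SC(C)(C)[C@@H]2C(=O)OC(c1ccccc1)c1ccccc1` is the next step from compound 3: methyl in place of 4-nitrophenyl on a carbonyl carbon. Within the data shown here, only one measured step touches the same carbonyl carbon, a 1.2-fold lower number from compound 1 to compound 3 (0.09 log units; within the scatter), an exchange of one ring for another that left the number where it was. Among the measured compounds shown here, no measured step shows what happens when the ring is removed altogether, so the expectation rests on the flat picture seen so far. Compound 4 is therefore expected to stay within the scatter of compound 3, a step of a 1.4-fold higher number from compound 3 to compound 4 (0.13 log units; within the scatter), with an estimated value of 60000 nM, between 25000 nM and 150000 nM.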

Compound 4, half-maximal inhibitory concentration: 51900 nM
For compound 4 the middle estimate is 1.2-fold (0.06 log units) above the measured one; the measured number falls inside the stated range.
By their numbers in this assay, from the lowest: compounds 3, 4, 1 and 2 (each within the scatter of the next).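

Until now, this carbonyl carbon had only shown one ring exchanged for another. Compound 4 shows that the ring can be replaced by a single methyl while the number in this assay stays within the scatter, both against the 4-nitrophenyl group (a 1.2-fold higher number from compound 3 to compound 4 (0.07 log units; within the scatter)) and against the furan-2-yl group (a 1.0-fold lower number from compound 1 to compound 4 (0.02 log units; within the scatter)). Among these three compounds, then, the group on this carbonyl carbon makes no difference that can be read, and nothing measured here offers a reason for that.

From the compounds shown here alone, it remains open whether any group at this place can move the number beyond the scatter, for instance a longer chain, an amine or a carboxylic acid. Whether changes elsewhere on the shared core would matter more is also unanswered.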